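Thioether tail exchange on the ethoxyphenyl core

The source may hold more compounds than are shown below. What is called first, only, known or untested is meant among the compounds shown, and "the series" means these compounds.

Compound 1 `N#Cc1c(N)nc(SCc2ncc[nH]2)c(C#N)c1-c1ccc(OCC2CC2)cc1`: 474 nM
Compound 2 `CCOc1ccc(-c2c(C#N)c(N)nc(SCc3ncc[nH]3)c2C#N)cc1`: 85 nM

The two measured compounds share a core and differ only in the ether chain. In an assay on CHO cells for displacement of a labelled ligand from adenosine receptor A3 (Homo sapiens), read by scintillation counting, with a stated time of 120 min (on this read-out lower numbers stand for stronger inhibition and higher numbers for weaker inhibition), compound 1 gives 474 nM, while compound 2 gives 85 nM. The step of a 5.6-fold lower number from compound 1 to compound 2 (0.75 log units; beyond the scatter) is beyond the scatter, so compound 2 stands as the lower of the two numbers and is the nearer starting point for the next change.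

Compound 3 `CCOc1ccc(-c2c(C#N)c(N)nc(SCC(=O)NC)c2C#N)cc1` keeps the ethoxy group of compound 2 and alters the thioether tail: methylcarbamoyl in place of 1H-imidazol-2-yl on a saturated chain carbon bound to a sulfur. Among the compounds with values here, no measured step touches this tail, since the only step seen, a 5.6-fold lower number from compound 1 to compound 2 (0.75 log units; beyond the scatter), concerns the ether chain on the other side of the core. The measured data therefore give no direction for this change. Compound 3 is expected to lie near compound 2, with a step of a 1.8-fold higher number from compound 2 to compound 3 (0.25 log units; within the scatter) that may not exceed the scatter. The estimate for compound 3 in this assay is 150 nM, within a range from 40 nM to 600 nM.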

Compound 3, inhibition constant: 834 nM
Compound 3: the middle estimate sits 5.6-fold (0.75 log units) below what was measured; measured number above the stated range.
By their numbers in this assay, from the lowest: compound 2; then compounds 1 and 3 (each within the scatter of the next).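

Within the data shown here, the thioether tail proves sensitive to change in this assay: methylcarbamoyl in place of 1H-imidazol-2-yl on a saturated chain carbon bound to a sulfur gives a 9.8-fold higher number from compound 2 to compound 3 (0.99 log units; beyond the scatter), the first reading at this position, where the earlier pair had varied only the ether chain. Among these compounds, the step lies beyond the scatter even though the two groups match in their counts of hydrogen-bond donors and acceptors and neither carries a net charge, so those counts alone do not separate them; the five-membered aromatic ring of the leaving group has no counterpart in the entering group, which is open-chain and carries a double bond outside aromatic rings. Nothing available accounts for the loss, and the data give no reason for it.

Going by these compounds, whether the ring itself matters remains open, and a phenyl ring, a pyridine ring or a simple primary amide on the same saturated chain carbon would help to separate ring from amide. Among the compounds shown here, also open is whether the two changes act independently, since the cyclopropyl ether of compound 1 is seen only with the 1H-imidazol-2-yl tail and the methylcarbamoyl tail only with the ethoxy group.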